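An Ethyl Extension on a Saturated Chain

This account rests on a few compounds, and the source may have more. Where it says the series, first, only, none or still open, it means among the compounds named here.

In a physicochemical assay for solubility, in phosphate buffer, measured as kinetic solubility, at pH 7.4, tested at 250 uM (a higher number here means a more soluble compound, a lower number a less soluble compound), compound 1 `CCCCCCNc1ccc(C(=O)O)cc1S(N)(=O)=O` gives 238000 nM. Compound 2 `CCCCCCCCNc1ccc(C(=O)O)cc1S(N)(=O)=O` gives > 250000 nM, which is a limit of the assay and not a number. Compound 3 `CCCCCCNc1ccc(C(=O)O)cc1S(=O)(=O)NC` gives 247000 nM, a value within the scatter of compound 1, so the two cannot be told apart.

Compound 4 `CCCCCCCCNc1ccc(C(=O)O)cc1S(=O)(=O)NC` differs from compound 3 by a single change on the saturated chain: ethyl in place of hydrogen on a saturated chain carbon, six bonds along the chain from a nitrogen on an aromatic ring. The same change has one measured example, an at least 1.0-fold higher number from compound 1 to compound 2 (0.02 log units; that floor lies within the scatter). That step is only a floor, and it lies within the scatter. The other measured step is methyl in place of hydrogen on a sulfonamide nitrogen, a 1.0-fold higher number from compound 1 to compound 3 (0.02 log units; within the scatter), which also stays within the scatter. Neither example therefore points to a real shift, so no step beyond the scatter is expected in this assay. The estimated step is a 1.0-fold lower number from compound 3 to compound 4 (0.01 log units; within the scatter). Compound 4 is expected at 240000 nM, with an estimated range of 170000 nM to 250000 nM, though the assay may report only a limit.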

Compound 4, solubility: 53000 nM
Compound 4: the middle estimate sits 4.5-fold (0.66 log units) above what was measured; measured number below the stated range.
By their numbers in this assay, from the lowest: compound 4; then compounds 1 and 3 (each within the scatter of the next). At a limit, above all of these: compound 2.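

In this assay, within the data shown here, the ethyl change at this place on the saturated chain now gives a readable step, a 4.7-fold lower number from compound 3 to compound 4 (0.67 log units; beyond the scatter), where its only earlier example was a floor within the scatter. Methyl on the sulfonamide nitrogen, with the longer chain in place, gives an at least 4.7-fold lower number from compound 2 to compound 4 (0.67 log units; beyond the scatter), although with the shorter chain the same change stayed within the scatter. The reading of each change therefore depends on what the other place carries, and any step from compound 2 remains open-ended: the limit of > 250000 nM in this assay, at which 1 of the 4 values shown sits.

On these data alone, whether a still longer chain would lower the number further remains open, as does whether an ethyl on the sulfonamide nitrogen would act like methyl. An amine or a hydroxyl at the end of the chain is also untested among the compounds shown, so four compounds cannot explain the drop.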